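The source may hold more compounds than are shown below. What is called first, only, known or untested is meant among the compounds shown, and "the series" means these compounds.

Measured so far in an ADME assay on HeLa cells (Homo sapiens) for cytotoxicity, read by ATP content, with a stated time of 3 days; on this read-out higher numbers stand for lower toxicity in this test and lower numbers for higher toxicity in this test:
compound 1 `CS(=O)(=O)CCCn1c(Cn2c(=O)n(C3CC3)c3ccncc32)cc2cc(Cl)ccc21`: > 50000 nM, a limit of the assay rather than a number.
compound 2 `N#CCCCn1c(Cn2c(=O)n(-c3ccc(C(=O)NC4CC4)cc3)c3ccncc32)cc2cc(Cl)ccc21`: > 50000 nM, also a limit of the assay.
compound 3 `O=c1n(Cc2nc3ncccc3n2CCCCO)c2cnccc2n1C1CC1`: > 100000 nM, again a limit.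

Compound 2 therefore stands at the limit of > 50000 nM in this assay, at which 2 of the 3 values shown sit, with no number of its own to place it. Going by the values given here, nothing so far resolves a difference among the three in this assay. Compound 4 `N#CCCCn1c(Cn2c(=O)n(-c3ccncn3)c3ccncc32)cc2cc(Cl)ccc21` has not yet been measured; it changes (pyrimidin-4-yl in place of 4-(cyclopropylcarbamoyl)phenyl on an aromatic nitrogen). Among the compounds with values here, no step between two measured compounds exists to calibrate this change, so no shift beyond the usual scatter is expected in this assay, and a further limit is the most likely outcome. The estimate for compound 4 is 50000 nM, range 25000 nM to 100000 nM, meaning an expected step of a number no higher from compound 2 to compound 4 (the limit leaves the size open).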

Compound 4, half-maximal cytotoxic concentration: > 50000 nM
Compound 4 ended at the assay's limit (the forecaster's own chance of this, stated with the estimate: 85%); the middle value sits exactly at the limit.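

No step can be read from compound 2 to compound 4, as both rest at a limit in this assay: the limit of > 50000 nM in this assay, at which 3 of the 4 values shown sit.

Left open is whether pyrimidin-4-yl in place of 4-(cyclopropylcarbamoyl)phenyl shifts the half-maximal cytotoxic concentration at all.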